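Working notes: removing the piperazine from compound 3

This account rests on a few compounds, and the source may have more. Where it says the series, first, only, none or still open, it means among the compounds named here.

Compound 1 (`COc1ncc(-c2ccc3ncc(NCC4CCCCC4)c(OC)c3c2)cc1NS(=O)(=O)c1ccc(F)cc1F`) gives 9000 nM
Compound 2 (`CCNc1cnc2ccc(-c3cnc(OC)c(NS(=O)(=O)c4ccc(F)cc4F)c3)cc2c1OC`) gives 4820 nM
Compound 3 (`COc1ncc(-c2ccc3ncc(NC(=O)CN4CCN(C)CC4)c(OC)c3c2)cc1NS(=O)(=O)c1ccc(F)cc1F`) gives 1730 nM

In a functional assay on PC-3 cells (Homo sapiens) for antiproliferative activity, read by sulforhodamine B assay, with a stated time of 72 h (a lower number here means a stronger inhibitor, a higher number a weaker inhibitor), compound 3 has the lowest of the three numbers at 1730 nM and compound 2 lies nearest to it. The next analogue is compound 4 (`COc1ncc(-c2ccc3ncc(NC(C)=O)c(OC)c3c2)cc1NS(=O)(=O)c1ccc(F)cc1F`), the acetamido member, which has hydrogen in place of 4-methylpiperazin-1-yl on a saturated chain carbon bound to a carbonyl carbon.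

For the measured compounds named here, two measured steps bear on this change. Putting ((4-methylpiperazin-1-yl)methyl)carbonyl in place of ethyl on a nitrogen on an aromatic ring gave a 2.8-fold lower number from compound 2 to compound 3 (0.45 log units; beyond the scatter) and putting it in place of cyclohexylmethyl gave a 5.2-fold lower number from compound 1 to compound 3 (0.72 log units; beyond the scatter) as the larger step. Methyl in place of cyclohexyl gave a 1.9-fold lower number from compound 1 to compound 2 (0.27 log units; within the scatter) as a step. Going by the values given here, no measured pair separates the carbonyl from the 4-methylpiperazin-1-yl, and compound 4 keeps the carbonyl.

A modest move to a higher number is therefore expected in this assay with part of a 2.8-fold lower number from compound 2 to compound 3 (0.45 log units; beyond the scatter) gain given back or slightly more. This estimate means an expected 2.2-fold higher number from compound 3 to compound 4 (0.34 log units; beyond the scatter) for this change. The estimated value for compound 4 is 3800 nM within an expected range of 1300 nM to 10000 nM on this read-out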

Compound 4, half-maximal inhibitory concentration: 1240 nM
The estimate for compound 4 lay 3.1-fold (0.49 log units) above the measured number; the measured number lies below the stated range.
By their numbers in this assay, from the lowest: compounds 4 and 3 (each within the scatter of the next); then compounds 2 and 1 (each within the scatter of the next).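

In this assay, hydrogen in place of 4-methylpiperazin-1-yl on a saturated chain carbon bound to a carbonyl carbon gives a 1.4-fold lower number from compound 3 to compound 4 (0.14 log units; within the scatter) and so leaves the number unresolved from that of compound 3 once the whole ring is gone. Acetyl in place of ethyl gives a 3.9-fold lower number from compound 2 to compound 4 (0.59 log units; beyond the scatter) and acetyl in place of cyclohexylmethyl gives a 7.3-fold lower number from compound 1 to compound 4 (0.86 log units; beyond the scatter) on the same nitrogen, so among these four compounds both members with a carbonyl on that nitrogen stand below both members without one, and none goes against this. The earlier compounds could not separate the carbonyl from the 4-methylpiperazin-1-yl, and no measurement shown here explains these steps.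

From the compounds shown here alone, it remains open whether a longer chain such as propanoyl, or a primary amine or a carboxylic acid on the saturated chain carbon, would hold the number at this level. Also open, going by these compounds, is whether the carbonyl itself is required, which a methanesulfonyl group on the same nitrogen would test.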